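Swapping One Halogen on Compound 2

The source may hold more compounds than are shown below. What is called first, only, known or untested is meant among the compounds shown, and "the series" means these compounds.

Compound 1 `Cc1cccc(-n2cc(-c3cccc(NS(=O)(=O)c4c[nH]c(=O)[nH]c4=O)c3)nn2)c1` and compound 2 `O=c1[nH]cc(S(=O)(=O)Nc2cccc(-c3cn(-c4ccccc4F)nn3)c2)c(=O)[nH]1` share one core and differ only in the group carried on an aromatic nitrogen. In a functional assay on SGC-7901 cells (Homo sapiens) for antiproliferative activity, read by MTT assay, with a stated time of 24 h (on this read-out higher numbers stand for weaker inhibition and lower numbers for stronger inhibition), compound 1 gives 9100 nM, and compound 2 gives 16000 nM. Of the two numbers shown, the one for compound 2 is the higher, yet the step of a 1.8-fold higher number from compound 1 to compound 2 (0.25 log units; within the scatter) lies within the scatter, so the two compounds are not distinguished by this assay.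

Compound 3 `O=c1[nH]cc(S(=O)(=O)Nc2cccc(-c3cn(-c4ccccc4Cl)nn3)c2)c(=O)[nH]1` is the next step out from compound 2: chloro in place of fluoro on an aromatic carbon. Among the compounds with values here, the only measured step, a 1.8-fold higher number from compound 1 to compound 2 (0.25 log units; within the scatter), concerns a different exchange, 2-fluorophenyl for 3-methylphenyl, and stayed within the scatter; it does not speak directly to a halogen swap, and no other measured pair covers one. With nothing pointing in either direction, compound 3 is expected to move only by a 1.1-fold lower number from compound 2 to compound 3 (0.06 log units; within the scatter) in this assay, which is no step beyond the scatter. The estimate for compound 3 is therefore 14000 nM, with a range from 6000 nM to 35000 nM.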

Compound 3, half-maximal inhibitory concentration: 3010 nM
Compound 3: middle estimate off by 4.7-fold (0.67 log units), on the high side; measured number below the stated range.
By their numbers in this assay, from the lowest: compound 3; then compounds 1 and 2 (each within the scatter of the next).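

In this assay, the exchange of fluoro for chloro on an aromatic carbon, ortho to a large group, gives a 5.3-fold lower number from compound 2 to compound 3 (0.73 log units; beyond the scatter), the first step among these compounds to pass beyond the scatter, and it shows that this place on the aromatic ring responds to which halogen it carries, even though the exchange swaps one heavy atom for one heavy atom and leaves the hydrogen-bond donor and acceptor counts at zero. The change also separates the 2-chlorophenyl compound from the 3-methylphenyl one, with a 3.0-fold lower number from compound 1 to compound 3 (0.48 log units; beyond the scatter), whereas 2-fluorophenyl in place of 3-methylphenyl had given only a 1.8-fold higher number from compound 1 to compound 2 (0.25 log units; within the scatter), a step within the scatter. Nothing available bears on why chloro and fluoro part here, so the result stands as an observation without an explanation.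

The compounds shown leave open whether bromo, methoxy or an amine at this same place would follow chloro or fluoro in this cell read-out. They also leave open whether the step from fluoro to chloro would hold if the shared core were changed elsewhere.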